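A few compounds are considered here, and "the series" means these few. Any claim that something is new, unique, unknown or untested is made for them only; others in the source may bear on it.

Compound 1 `CCC(CC)(c1nnc[nH]1)c1ccc(-c2ccc3cc(F)cc(F)c3c2)[nH]c1=O` gives 350 nM in a functional assay on CHO cells for antagonist activity at prostaglandin E2 receptor EP3 subtype (Homo sapiens), read by cAMP accumulation; on this read-out lower numbers stand for stronger inhibition and higher numbers for weaker inhibition.
Compound 2 `CC(C)C(O)(C(=O)O)c1ccc(-c2ccc3ccccc3c2)[nH]c1=O` gives 1580 nM in this assay.
Compound 3 `Cc1nc(C(c2ccc(-c3ccc4cccc(F)c4c3)[nH]c2=O)C(C)C)[nH]c1C` gives 50 nM in this assay.

Of the three measured values, compound 3 stands lowest; compound 1 is its nearest neighbour, and compound 2 lies furthest from it, both gaps being beyond the usual scatter. Compound 4 `CC(C)C(CC(N)=O)c1ccc(-c2ccc3cccc(F)c3c2)[nH]c1=O` has not yet been measured. It differs from compound 3 in one place: carbamoylmethyl in place of 4,5-dimethyl-1H-imidazol-2-yl on a saturated chain carbon bound to an aromatic carbon and a saturated chain carbon. Within the data shown here, no measured pair differs in only one place, so no measured step can guide the size of this change. The step from compound 3 to compound 4 is expected to move toward a weaker number in this assay, by about a 12-fold higher number from compound 3 to compound 4 (1.08 log units; beyond the scatter). Compound 4 is accordingly estimated at 600 nM, with a range from 150 nM to 3000 nM.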

Compound 4, half-maximal inhibitory concentration: 53 nM
The estimate for compound 4 lay 11-fold (1.05 log units) above the measured number; the whole stated range lies above it.
By their numbers in this assay, from the lowest: compounds 3 and 4 (each within the scatter of the next); then compound 1; then compound 2.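

Putting carbamoylmethyl in place of 4,5-dimethyl-1H-imidazol-2-yl on this saturated chain carbon gives in this assay a 1.1-fold higher number from compound 3 to compound 4 (0.03 log units; within the scatter) and so leaves the two compounds level within the scatter. At this position, then, with this core, the five-membered aromatic ring is not needed for a number of this size, and an open group without a ring serves as well. Nothing available bears on why the two groups match.

The compounds shown leave open whether a nitrile, an amine or a carboxylic acid on this carbon would hold the number. They also leave open whether a longer chain ending in the same amide would do so.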